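This account rests on a few compounds, and the source may have more. Where it says the series, first, only, none or still open, it means among the compounds named here.

In a functional assay on DU-145 cells (Homo sapiens) for inhibition, read by MTT assay, with a stated time of 48 h (on this read-out higher numbers stand for weaker inhibition and lower numbers for stronger inhibition), three compounds with a shared core have been measured. Compound 1 `CS(=O)(=O)Nc1ccc(-n2cc(OCc3ccccc3)nn2)cc1Oc1ccccc1` gives 10700 nM while compound 2 `CS(=O)(=O)Nc1ccc(-n2cc(COc3ccc4ccccc4c3)nn2)cc1Oc1ccccc1` gives 9100 nM and compound 3 `CS(=O)(=O)Nc1ccc(-n2cc(COc3ccc(Cl)cc3)nn2)cc1Oc1ccccc1` gives 6400 nM as its reading, which places compound 3 within the usual scatter of both others. Compound 4 `CS(=O)(=O)Nc1ccc(-n2cc(COc3ccc([N+](=O)[O-])cc3)nn2)cc1Oc1ccccc1` is still unmeasured and differs from compound 3 by one change, nitro in place of chloro on an aromatic carbon in which nitro takes the place of chloro on an aromatic carbon. Among the compounds with values here, no measured step makes this swap. The closest guides are a 1.7-fold lower number from compound 1 to compound 3 (0.22 log units; within the scatter) and a 1.4-fold lower number from compound 2 to compound 3 (0.15 log units; within the scatter) and both stay within the scatter even though other groups were exchanged. The expected change in this assay is therefore a 1.1-fold higher number from compound 3 to compound 4 (0.04 log units; within the scatter) and nothing beyond the scatter is expected. Compound 4 is estimated at 7000 nM with 3000 nM to 15000 nM as the expected range.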

Compound 4, half-maximal inhibitory concentration: 7200 nM
The estimate for compound 4 lay 1.0-fold (0.01 log units) below the measured number; the range from low to high includes it.
By their numbers in this assay, from the lowest: compounds 3, 4, 2 and 1 (each within the scatter of the next).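

In this assay, nitro replaces chloro on an aromatic carbon para to a large group (a 1.1-fold higher number from compound 3 to compound 4 (0.05 log units; within the scatter)), so three heavy atoms, with two hydrogen-bond acceptors, take the place of one chlorine without a shift beyond the scatter. Compound 4 also stays within the scatter in the two wider exchanges (a 1.3-fold lower number from compound 2 to compound 4 (0.10 log units; within the scatter)) and (a 1.5-fold lower number from compound 1 to compound 4 (0.17 log units; within the scatter)). Nothing available explains this lack of separation.

As far as these compounds go, whether an amine or a carboxylic acid at this position would give a step beyond the scatter stays open. From the compounds shown here alone, the effect of any change to the shared core also stays open.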